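This account rests on a few compounds, and the source may have more. Where it says the series, first, only, none or still open, it means among the compounds named here.

Measured so far:
compound 1 `Cc1ccc(CC(C)C(=O)N2CCN(c3ccc(C(F)(F)F)cc3[C@@H](N)CC(C)C)CC2)cc1C`, 240 nM
compound 2 `CC(C)C[C@H](N)c1cc(C(F)(F)F)ccc1N1CCN(C(=O)COc2cccc(Cl)c2Cl)CC1`, 2500 nM
compound 3 `COc1ccc(CC(C)C(=O)N2CCN(c3ccc(C(F)(F)F)cc3[C@@H](N)CC(C)C)CC2)cc1`, 120 nM

In an assay on HEK293 cells for displacement of a labelled ligand from Melanocortin receptor 4 (Homo sapiens) (a lower number here means a stronger inhibitor, a higher number a weaker inhibitor), compound 3 gives the lowest of the three numbers, though its step to compound 1 is within the scatter, and a 2.0-fold lower number from compound 1 to compound 3 (0.30 log units; within the scatter). The group on the carbonyl carbon is where the large movements sit: a 10-fold higher number from compound 1 to compound 2 (1.02 log units; beyond the scatter) and a 21-fold lower number from compound 2 to compound 3 (1.32 log units; beyond the scatter).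

Compound 4 `CC(C)C[C@H](N)c1cc(C(F)(F)F)ccc1N1CCN(C(=O)CC(C)C(=O)c2ccc(Cl)cc2)CC1` changes that same position: 2-((4-chlorophenyl)carbonyl)propyl in place of 1-(4-methoxybenzyl)ethyl on a carbonyl carbon. The entering group keeps a branched chain ending in an aromatic ring, unlike the (2,3-dichlorophenoxy)methyl of compound 2, but adds a second carbonyl. Given that swaps here have moved this assay by large amounts in both directions, a moderate rise from compound 3 is expected, a 3.3-fold higher number from compound 3 to compound 4 (0.52 log units; beyond the scatter). Compound 4 is estimated at 400 nM, range 100 nM to 1600 nM.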

Compound 4, inhibition constant: 1100 nM
For compound 4 the middle estimate is 2.8-fold (0.44 log units) below the measured one, within the range that was stated.
By their numbers in this assay, from the lowest: compounds 3 and 1 (each within the scatter of the next); then compound 4; then compound 2.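

In this assay the 2-((4-chlorophenyl)carbonyl)propyl group on the carbonyl carbon brings a 9.2-fold higher number from compound 3 to compound 4 (0.96 log units; beyond the scatter) and a 4.6-fold higher number from compound 1 to compound 4 (0.66 log units; beyond the scatter) but also a 2.3-fold lower number from compound 2 to compound 4 (0.36 log units; beyond the scatter) and so places compound 4 at an intermediate level at this position. A branched chain ending in an aromatic ring therefore does not by itself keep the numbers of compound 1 and compound 3. No measurement on hand accounts for these steps.

Going by these compounds, the chain carbonyl and the chlorine enter together, so their separate contributions remain open. Also open, on these data alone, is how an alcohol in place of that carbonyl, or an amine on the chain, would read here.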